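The source may hold more compounds than are shown below. What is called first, only, known or untested is meant among the compounds shown, and "the series" means these compounds.

Measured compounds:
Compound 1, `Nc1sc(-c2ccccc2)c(-c2ccccc2)c1C(=O)c1ccc(Cl)cc1`, in an assay on CHO cells for displacement of a labelled ligand from adenosine receptor A3 (Homo sapiens), read by scintillation counting, tested at 10 uM (on this read-out lower numbers stand for less inhibition and higher numbers for more inhibition at the one concentration tested (going by the name of the read-out)), gives 1%.
Compound 2, `CC(C)(C)Cc1c(-c2ccc(F)cc2F)sc(N)c1C(=O)c1ccc(Cl)cc1`, in this assay gives 1%.

On these numbers compound 2 stands level with compound 1. The two values agree at the digits given, and a gap of that size lies within the usual scatter of repeated measurements, so no order or change between the two compounds can be read from them. Both show very little displacement of the labelled ligand at the single concentration tested.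

Compound 3, `CC(C)(C)Cc1c(-c2ccc(Cl)c(Cl)c2)sc(N)c1C(=O)c1ccc(Cl)cc1`, has not yet been measured. It differs from compound 2 in one place: 3,4-dichlorophenyl in place of 2,4-difluorophenyl on an aromatic carbon. Among the compounds with values here, no step between measured compounds of this kind exists, so the size of the expected step rests on the general picture. Within the data shown here, compound 1 and compound 2 both sit at the bottom of the scale, and nothing among the measured compounds points to a step beyond the scatter in this assay in either direction.

For compound 3 the expected value in this assay is estimated at 3%, with a likely range from 0% to 15%. The step this estimate means, a number 2 percentage points higher from compound 2 to compound 3 (within the scatter), is expected to stay within the scatter.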

Compound 3, a percentage reported as inhibition, at one concentration (the size of the read-out at that concentration, not a potency): 1%
Estimate against measurement, compound 3: 2 percentage points above; the range from low to high includes it.
By their numbers in this assay, from the lowest: compounds 1, 2 and 3 (each within the scatter of the next).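

In this assay, putting 3,4-dichlorophenyl in place of 2,4-difluorophenyl on the aromatic carbon next to the ring sulfur gives no change at the digits printed from compound 2 to compound 3 (within the scatter). Within the data shown here, compounds 1 and 2 differ in more than one place, so this is the only direct reading of a change at this position, and it shows that exchanging one of these two halogen-bearing phenyl groups for the other leaves the read-out at the bottom of the scale. With both compounds this low, the pair cannot show whether the two groups would behave differently on a compound with clearer displacement of the labelled ligand, and no measurement shown here offers an explanation for the result.

From the compounds shown here alone, whether a phenyl group carrying an amine or a carboxylic acid, or a longer chain, at this same position would give a reading beyond the scatter remains open. Also open, going by these compounds, is whether replacing the neopentyl group with a smaller chain such as ethyl, or changing the amino group, would raise the reading in this assay.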